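Benzyl for Fluorophenyl on the Ring Amine of Compound 1

The compounds below may be only part of what the source reports. "The series", "measured", "known", "first", "only" and "open" are said of these compounds alone.

Of the compounds shown here, three built on a shared core have been measured in a functional assay on HeLa cells (Homo sapiens) for antiproliferative activity, read by CCK-8 assay, with a stated time of 72 h, tested at 2 uM; on this read-out higher numbers stand for a stronger effect at the one concentration tested and lower numbers for a weaker effect. Compound 1 `Nc1ccccc1NC(=O)c1ccc(CSC(=S)N2CCN(c3ccc(F)cc3)CC2)cc1` gives 60.8% there and stands highest of the three numbers. Compound 2 `CC1CCN(C(=S)SCc2ccc(C(=O)Nc3ccccc3N)cc2)CC1` gives 46.8%, a number beyond the scatter below compound 1, and compound 3 `CN(Cc1ccncc1)C(=S)SCc1ccc(C(=O)Nc2ccccc2N)cc1` gives 29.5%, the furthest below compound 1. Within the data shown here, the only single-place step among the measured compounds is a number 17.3 percentage points lower from compound 2 to compound 3 (beyond the scatter), a change on the thiocarbonyl carbon rather than on the ring amine.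

Compound 4 `Nc1ccccc1NC(=O)c1ccc(CSC(=S)N2CCN(Cc3ccccc3)CC2)cc1` is not yet measured. It differs from compound 1 in one place: benzyl in place of 4-fluorophenyl on an amine nitrogen in a ring. Among the measured compounds shown here, no measured step touches this position, so nothing measured bears directly on the change; the one known step, on the thiocarbonyl carbon, was modest in size. By analogy the account expects a modest step in this assay for compound 4 as well, most likely downward but possibly none beyond the scatter, since the group leaving and the group entering match in size and in the count of donors and acceptors. Compound 4 is therefore estimated at 50%, within a range from 32% to 66%, which means an expected step of a number 10.8 percentage points lower from compound 1 to compound 4 (beyond the scatter).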

Compound 4, a percentage reported as inhibition, at one concentration (the size of the read-out at that concentration, not a potency): 20.6%
Beside the measured number, compound 4's estimate is 29.4 percentage points above it, outside the stated range (below it).
By their numbers in this assay, from the lowest: compounds 4 and 3 (each within the scatter of the next); then compound 2; then compound 1.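

Among these compounds, at this position, on an amine nitrogen in a ring, this assay gives the first measured step, a number 40.2 percentage points lower from compound 1 to compound 4 (beyond the scatter), and it is large, whereas the one earlier step, on the thiocarbonyl carbon, was modest. The position therefore responds strongly to this exchange, even though 4-fluorophenyl and benzyl have the same count of heavy atoms, the same single six-membered aromatic ring of carbon only, and no hydrogen-bond donors or acceptors. Nothing available here accounts for the size of this step.

The exchange removes the fluorine and also places a carbon between the aromatic ring and the ring nitrogen, so the compounds shown leave open which of the two changes goes with the step; a plain phenyl or a 4-fluorobenzyl on that nitrogen would separate them. They also leave open whether the step would hold at other concentrations, as the read-out reports the size of the effect at a single concentration and not a potency.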